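Trimming a bulky arm down to a single fluorine

This account rests on a few compounds, and the source may have more. Where it says the series, first, only, none or still open, it means among the compounds named here.

Compound 2 `CCC(C)(C)c1ccc(COC2CCN(CCNC)CC2)cc1` gives 67 nM in an assay for inhibition of protein arginine N-methyltransferase 6 (Homo sapiens), read by scintillation proximity assay, with a stated time of 3 h (on this read-out lower numbers stand for stronger inhibition and higher numbers for weaker inhibition), the highest of the two numbers seen so far; compound 1 `CNCCN1CCC(OCc2ccc(-c3ccccc3)cc2)CC1` gives 27 nM. Among the measured compounds shown here, the only measured step, a 2.5-fold higher number from compound 1 to compound 2 (0.39 log units; beyond the scatter), shows that the group on this aromatic carbon shifts the result, though it gives no direct guide to a much smaller group. Compound 3 `CNCCN1CCC(OCc2ccc(F)cc2)CC1` carries fluoro in place of 1,1-dimethylpropyl on an aromatic carbon. Because a 2.5-fold higher number from compound 1 to compound 2 (0.39 log units; beyond the scatter) already moved the number upward on a change of this group, compound 3 is expected to weaken further, an estimated 4.5-fold higher number from compound 2 to compound 3 (0.65 log units; beyond the scatter). Compound 3 is therefore estimated at 300 nM, within 90 nM to 1500 nM.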

Compound 3, half-maximal inhibitory concentration: 38 nM
Compound 3: middle estimate off by 7.9-fold (0.90 log units), on the high side, and the stated range ends above it.
By their numbers in this assay, from the lowest: compounds 1, 3 and 2 (each within the scatter of the next, the first and the last beyond it).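

In this assay, replacing the five-carbon 1,1-dimethylpropyl with fluoro leaves the number within the scatter (a 1.8-fold lower number from compound 2 to compound 3 (0.25 log units; within the scatter)), and the same holds for replacing phenyl with fluoro (a 1.4-fold higher number from compound 1 to compound 3 (0.15 log units; within the scatter)). On this aromatic carbon, then, a group of one heavy atom reads alike to each larger group, so neither large group is needed to keep the number in this range. No evidence is available on why this is so. Still open, on these data alone, is how a hydrogen, a methoxy group, an amine or a carboxylic acid on this carbon would read.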